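This account rests on a few compounds, and the source may have more. Where it says the series, first, only, none or still open, it means among the compounds named here.

In a functional assay on ECV-304 cells (Homo sapiens) for cytotoxicity, read by MTT assay, with stated times of 24 h and 12 h (on this read-out higher numbers stand for an effect only at larger amounts of compound and lower numbers for an effect already at smaller amounts), compound 1 (`CCOC(=O)/C=C/c1cc(Cl)ccc1OCc1nc(C)c(C)nc1C`) gives 16900000 nM and compound 2 (`Cc1nc(C)c(COc2ccccc2/C=C/C(=O)O)nc1C`) gives 499000 nM as the lower of the two numbers, a gap beyond the scatter. Compound 3 (`Cc1nc(C)c(COc2ccc(Cl)cc2/C=C/C(=O)O)nc1C`) departs from compound 2 by one change (chloro in place of hydrogen on an aromatic carbon), chloro in place of hydrogen on an aromatic carbon. For the measured compounds named here, compound 1 carries a chloro too but is an ethyl ester, so no measured pair isolates this change. No step beyond the scatter is expected in this assay, and the estimated step (a 1.2-fold lower number from compound 2 to compound 3 (0.10 log units; within the scatter)) is small and without firm direction. For compound 3 the expected value is 400000 nM within an estimated range from 100000 nM to 2000000 nM on this read-out.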

Compound 3, half-maximal effective concentration: 9310000 nM
Estimate against measurement, compound 3: 23-fold (1.37 log units) below, outside the stated range (above it).
By their numbers in this assay, from the lowest: compound 2; then compounds 3 and 1 (each within the scatter of the next).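

In this assay, for the compounds shown here, the chloro, on an aromatic carbon para to a large group and meta to a 2-carboxyethenyl group, gives a 19-fold higher number from compound 2 to compound 3 (1.27 log units; beyond the scatter) as a large step, which no earlier pair could show. With this chloro present, hydrogen in place of ethyl on the oxygen next to the carbonyl group gives a 1.8-fold lower number from compound 1 to compound 3 (0.26 log units; within the scatter) and so stays within the scatter. No measurement shown accounts for the size of the chloro step. On these data alone, whether fluoro or methoxy in this place would give a similar step remains open, as does how an ethyl ester would stand without the chloro.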